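Extending a phenyl group in a cell-based functional assay

The compounds below may be only part of what the source reports. "The series", "measured", "known", "first", "only" and "open" are said of these compounds alone.

Compound 1 `Cn1cncc1C(OCc1ccc(C#N)cc1C#Cc1ccccc1)c1ccc(C#N)cc1`: 0.1 nM
Compound 2 `Cn1cncc1C(OCc1ccc(C#N)cc1-c1ccccc1)c1ccc(C#N)cc1`: 140 nM

In a functional assay on NIH3T3 cells (Mus musculus) (on this read-out lower numbers stand for an effect already at smaller amounts and higher numbers for an effect only at larger amounts of compound), compound 2 gives the highest of the two numbers shown, far from compound 1. Among the measured compounds shown here, the one measured step, a 1400-fold higher number from compound 1 to compound 2 (3.15 log units; beyond the scatter), shows how strongly this part of the molecule matters. Compound 3 `Cn1cncc1C(OCc1ccc(C#N)cc1-c1ccc(-c2ccccc2)cc1)c1ccc(C#N)cc1` differs from compound 2 by phenyl in place of hydrogen on an aromatic carbon, which lengthens this group again. For the measured compounds named here, no measured step covers hydrogen to phenyl here, so the expectation rests only on that one large step. A lower number is expected for compound 3, with the step of a 4.7-fold lower number from compound 2 to compound 3 (0.67 log units; beyond the scatter), giving an estimate of 30 nM within 3 nM to 300 nM.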

Compound 3, half-maximal effective concentration: < 0.1 nM
Compound 3: no number, only a limit; the forecaster's own chance of this, stated with the estimate: 5%; at least 300-fold (2.47 log units) between middle value and limit.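

At this position, phenyl in place of hydrogen gives an at least 1400-fold lower number from compound 2 to compound 3 (3.14 log units; beyond the scatter) in this assay. The large rise seen with phenyl is therefore not fixed: a 4-phenylphenyl group also reaches a very low number, with no 2-phenylethynyl present. Compound 3 has only a limit of the assay, not a number: the limit of < 0.1 nM in this assay, at which 1 of the 3 values shown sits.

The data give a number no higher from compound 1 to compound 3 (the limit leaves the size open), so the size of this step cannot be read. As far as these compounds go, whether an amine or a carboxylic acid in place of the added phenyl would keep such a low number stays open.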